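Swapping the Ester Arm of Compound 3 for Isobutyl

This account rests on a few compounds, and the source may have more. Where it says the series, first, only, none or still open, it means among the compounds named here.

Compound 3 `CC(OC(=O)N1CCN(C(=O)c2nc(Nc3cc(C4CC4)[nH]n3)c3cc(Cl)ccc3n2)C[C@H]1C)OC(=O)C(C)(C)C` gives 65.3% in an assay for inhibition of serine/threonine-protein kinase PAK 4 (Homo sapiens), read by FRET and Z'-LYTE, with a stated time of 60 min, tested at 50 uM, in the presence of a further agent that is not named here (on this read-out lower numbers stand for a weaker effect and higher numbers for a stronger effect at the one concentration tested), the highest of the three numbers measured. Compound 2 `C[C@@H]1CN(C(=O)c2nc(Nc3cc(C4CC4)[nH]n3)c3cc(Cl)ccc3n2)CCN1C(=O)OCOC(=O)C(C)(C)C` gives 60.5%, and the gap a number 4.8 percentage points higher from compound 2 to compound 3 (within the scatter) is within the scatter, so the two cannot be ranked. Compound 1 `C[C@@H]1CN(C(=O)c2nc(Nc3cc(C4CC4)[nH]n3)c3cc(Cl)ccc3n2)CCN1C(=O)OC(C)(C)C` gives 36.4%, and the step of a number 28.9 percentage points higher from compound 1 to compound 3 (beyond the scatter) is clearly beyond the scatter, as is a number 24.1 percentage points higher from compound 1 to compound 2 (beyond the scatter). Compound 4 `CC(C)COC(=O)N1CCN(C(=O)c2nc(Nc3cc(C4CC4)[nH]n3)c3cc(Cl)ccc3n2)C[C@H]1C` is not yet measured; its change from compound 3 is isobutyl in place of 1-(((tert-butyl)carbonyl)oxy)ethyl on an oxygen next to a carbonyl group. Isobutyl resembles the tert-butyl of compound 1 more than the larger ester-bearing arm, so the step of a number 28.9 percentage points higher from compound 1 to compound 3 (beyond the scatter) is expected to be largely undone, giving a number 25.3 percentage points lower from compound 3 to compound 4 (beyond the scatter). Compound 4 is therefore expected to show about 40%, within 25% to 58%.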

Compound 4, a percentage reported as inhibition, at one concentration (the size of the read-out at that concentration, not a potency) in the serine/threonine-protein kinase PAK 4 assay: 46.9%
The estimate for compound 4 lay 6.9 percentage points below the measured number; the range from low to high includes it.
By their numbers in the serine/threonine-protein kinase PAK 4 assay, from the lowest: compound 1; then compound 4; then compounds 2 and 3 (each within the scatter of the next).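

In (the serine/threonine-protein kinase PAK 4 assay), isobutyl falls clearly short of both ester-bearing arms (a number 18.4 percentage points lower from compound 3 to compound 4 (beyond the scatter)) (a number 13.6 percentage points lower from compound 2 to compound 4 (beyond the scatter)), yet it also differs clearly from tert-butyl (a number 10.5 percentage points higher from compound 1 to compound 4 (beyond the scatter)), so even two small alkyl groups on this oxygen are told apart. In (a physicochemical assay, read by HPLC, in phosphate buffer, with a stated time of 2 h, at pH 7.4; a lower number here means that less of the compound is left, a higher number that more of the compound is left), compound 3 gives (90.5%) and compound 4 gives (99%), and this step (a number 8.5 percentage points higher from compound 3 to compound 4 (within the scatter)) does not rank them. Nothing measured here explains these differences.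

Still open, as far as these compounds go, is how a straight butyl chain or an arm ending in an amine would fare on this oxygen in either test.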